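The source may hold more compounds than are shown below. What is called first, only, known or untested is meant among the compounds shown, and "the series" means these compounds.

Compound 1 `Cc1ccc(S(=O)(=O)n2cc(-c3cc(C(F)(F)F)ccn3)c3ccccc32)cc1`: 49.9%
Compound 2 `Cc1ccc(S(=O)(=O)n2cc(-c3cc(C(F)(F)F)c(C#N)c(-c4cn(S(=O)(=O)c5ccc(C)cc5)c5cc(Br)ccc45)n3)c3ccc(Br)cc32)cc1`: 1.3%

In a functional assay on P388 cells (Mus musculus) for inhibition, tested at 100 uM (on this read-out lower numbers stand for a weaker effect and higher numbers for a stronger effect at the one concentration tested), compound 1 gives 49.9%, the higher of the two numbers, whereas compound 2 gives 1.3%, a gap that lies beyond the usual scatter. Among the measured compounds shown here, compound 2 differs from compound 1 in many places at once, so no single-change step between measured compounds is available. Compound 3 `Cc1ccc(S(=O)(=O)n2cc(-c3cc(C(F)(F)F)ccn3)c3cc(Br)ccc32)cc1` differs from compound 1 in one place only: bromo in place of hydrogen on an aromatic carbon. For the measured compounds named here, with no single-change step to lean on, the step of a number 4.9 percentage points lower from compound 1 to compound 3 (within the scatter) is expected to be small, probably none beyond the scatter. Compound 3 is expected to give 45%, with a range from 25% to 65%.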

Compound 3, a percentage reported as inhibition, at one concentration (the size of the read-out at that concentration, not a potency): 32.6%
For compound 3 the middle estimate is 12.4 percentage points above the measured one; the range from low to high includes it.
By their numbers in this assay, from the lowest: compound 2; then compound 3; then compound 1.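

In this assay, among the compounds shown here, the first single-change step is a number 17.3 percentage points lower from compound 1 to compound 3 (beyond the scatter) when bromo takes the place of hydrogen on this aromatic carbon. Activity at the one concentration tested therefore responds to a change at this position, and a single bromine atom is enough to produce a modest loss. Nothing measured here gives a reason for this drop. Still open, on these data alone, is whether a smaller halogen such as fluoro, or a methoxy group or an amine on the same carbon, would lower the read-out as well.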